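Trimming an Amine Substituent: Ethyl to Methyl

This account rests on a few compounds, and the source may have more. Where it says the series, first, only, none or still open, it means among the compounds named here.

Measured compounds:
Compound 1 `CCN(C)Cc1c(OC)cc(OC)c(C(=O)/C=C/c2ccccc2Cl)c1O`: 23300 nM
Compound 2 `COc1cc(O)c2c(=O)cc(-c3ccccc3Cl)oc2c1CN1CCCCC1`: 118000 nM

Two compounds have been run in a functional assay on Bel-7402 cells (Homo sapiens) for antiproliferative activity, with a stated time of 72 h; on this read-out higher numbers stand for weaker inhibition and lower numbers for stronger inhibition. Compound 1 gives 23300 nM, the lower of the two numbers. Compound 2, which has a different core, gives 118000 nM in this assay, a number that stands well beyond the scatter above that of compound 1. Within the data shown here, since the two differ in more than one place, their values show only that compound 1 is the stronger inhibitor of the pair.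

Compound 3 `COc1cc(OC)c(C(=O)/C=C/c2ccccc2Cl)c(O)c1CN(C)C` has not yet been measured. It keeps the core of compound 1 and differs from it in one place: hydrogen in place of methyl on a saturated chain carbon bound to an amine nitrogen. Among the measured compounds shown here, no step of this kind has been measured among the compounds in hand, so nothing directly supports a prediction of direction.

For the measured compounds named here, with no measured step of this kind to lean on, the step of a 1.1-fold higher number from compound 1 to compound 3 (0.03 log units; within the scatter) is expected to lie within the scatter, with no clear direction. Compound 3 is accordingly estimated at 25000 nM in this assay, with a range from 10000 nM to 60000 nM.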

Compound 3, half-maximal inhibitory concentration: 21800 nM
Compound 3: middle estimate off by 1.1-fold (0.06 log units), on the high side; low and high end bracket the measured number.
By their numbers in this assay, from the lowest: compounds 3 and 1 (each within the scatter of the next); then compound 2.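

In this assay, among these compounds, the change of ethyl to methyl gives a 1.1-fold lower number from compound 1 to compound 3 (0.03 log units; within the scatter), the first measured step at this place on a saturated chain carbon bound to an amine nitrogen. The earlier pair of compounds differed in more than one place and could say nothing about this position, whereas this step shows that, on the core of compound 1, exchanging ethyl(methyl)amino for dimethylamino leaves the number within the scatter, so this read-out cannot separate the two compounds. What lies behind this result cannot be said, as no measurement beyond the antiproliferative numbers themselves bears on it.

The compounds shown leave open whether this insensitivity extends to larger groups on the same nitrogen, such as a propyl chain, two ethyl groups or a ring amine such as morpholine, since one step of a single carbon marks out only a small part of what might sit there. Among the compounds shown here, they also leave open whether the amine itself matters, as no compound on this core carries a hydroxymethyl or a plain methyl group in place of the aminomethyl group.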